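Cyano in Place of Chloro: Expecting Compound 4

The source may report more compounds than this note shows. Statements on the series, on what has been measured and on what is new or still open speak of the compounds shown alone.

The three measured compounds share one core and were tested in an in vitro functional assay on HEK285-7 cells for antagonist activity at prostaglandin D2 receptor 2 (Homo sapiens), read by BRET and beta-arrestin recruitment; a lower number here means a stronger inhibitor, a higher number a weaker inhibitor. Compound 1 `Cc1nc(-c2ccc(Cl)cc2)c(CC(=O)O)s1` gives 41000 nM. Compound 2 `O=C(O)Cc1sc(C(c2ccccc2)c2ccc(F)cc2)nc1-c1ccc(Cl)cc1` gives 36 nM, and compound 3 `O=C(O)Cc1sc(C(c2ccc(F)cc2)c2ccc(F)cc2)nc1-c1ccc(Cl)cc1` gives 180 nM. Among these three numbers compound 3 holds the second highest: its nearest neighbour is compound 2, and its furthest is compound 1, whose number lies far above it. Going by the values given here, the single recorded step, a 5.0-fold higher number from compound 2 to compound 3 (0.70 log units; beyond the scatter), came from a fluoro in place of hydrogen on an aromatic carbon.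

Compound 4 `N#Cc1ccc(-c2nc(C(c3ccc(F)cc3)c3ccc(F)cc3)sc2CC(=O)O)cc1` differs from compound 3 in one place: cyano in place of chloro on an aromatic carbon. Among the compounds with values here, no measured step bears on this change; the only step known concerns a different group elsewhere in the molecule and says nothing about cyano against chloro. Within the data shown here, with no comparable step to lean on, a small shift in either direction or none beyond the scatter is the fairest expectation, while the uncertainty stays wide. Compound 4 is therefore expected to give about 250 nM in this assay, within a range of 60 nM to 1000 nM, which amounts to an expected step of a 1.4-fold higher number from compound 3 to compound 4 (0.14 log units; within the scatter).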

Compound 4, half-maximal inhibitory concentration: 1500 nM
The estimate for compound 4 lay 6.0-fold (0.78 log units) below the measured number, outside the stated range (above it).
By their numbers in this assay, from the lowest: compound 2; then compound 3; then compound 4; then compound 1.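

In this assay, going by these compounds alone, moving from 4-chlorophenyl to 4-cyanophenyl gives an 8.3-fold higher number from compound 3 to compound 4 (0.92 log units; beyond the scatter) and so shows for the first time that this position, on a six-membered aromatic ring of carbon only and para to a large group, is sensitive to what it carries. Chloro and cyano are not interchangeable here, and among these two compounds the chloro version is the stronger inhibitor. The swap replaces a single chlorine atom with a cyano group that adds a hydrogen-bond acceptor, but nothing measured here tells which feature of the change accounts for the weaker inhibition.

Among the compounds shown, only chloro and cyano occupy this position, so it remains open whether a methoxy group, an amine or a carboxylic acid would land nearer compound 3 or nearer compound 4. From the compounds shown here alone, it is also open whether the same swap would cost as much on the background of compound 2, since this step has been read on one background only.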